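The source may report more compounds than this note shows. Statements on the series, on what has been measured and on what is new or still open speak of the compounds shown alone.

Of the compounds shown here, three have so far been measured in an assay on isolated protein for antagonist activity at advanced glycosylation end product-specific receptor (Homo sapiens), read by ELISA, with a stated time of 60 min; a higher number here means a weaker inhibitor, a lower number a stronger inhibitor. Compound 1 `CCCCc1nc(-c2ccc(Oc3ccc(Cl)cc3)cc2)sc1-c1ccc(OCCCN(CC)CC)cc1` gives 2010 nM in this assay. Compound 2 `CCCCc1sc(NC(=O)c2ccc(OCCCN(CC)CC)cc2)nc1-c1ccc(Oc2ccc(Cl)cc2)cc1`, in which the two aryl parts are joined through an amide rather than directly, gives 5590 nM in this assay. Compound 3 `CCCCc1sc(-c2ccc(OCCCN3CCCCC3)cc2)nc1-c1ccc(Oc2ccc(Cl)cc2)cc1` gives 1840 nM in this assay, the lowest of the three numbers, though its gap to compound 1 lies within the usual scatter of repeated measurements and only its gap to compound 2 lies beyond it. Going by the values given here, since compound 1 and compound 3 differ in more than one place, their two values show only that the two compounds sit close together.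

Compound 4 `CCCCc1sc(-c2ccc(OCCCN(CC)CC)cc2)nc1-c1ccc(Oc2ccc(Cl)cc2)cc1` is not yet measured. It differs from compound 3 in one place: diethylamino in place of piperidin-1-yl on a saturated chain carbon, three bonds along the chain from an oxygen on an aromatic ring. Compound 1 already carries the diethylamino group on the same kind of chain, and its value in this assay sits close to that of compound 3, so a large shift from this one change is not expected. The step from compound 3 to compound 4 is expected to be small, a 1.1-fold higher number from compound 3 to compound 4 (0.04 log units; within the scatter), and to stay within the scatter in either direction. For compound 4 the estimate in this assay is 2000 nM, with a range from 900 nM to 4500 nM.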

Compound 4, half-maximal inhibitory concentration: 1720 nM
Beside the measured number, compound 4's estimate is 1.2-fold (0.07 log units) above it; measured number inside the range.
By their numbers in this assay, from the lowest: compounds 4, 3 and 1 (each within the scatter of the next); then compound 2.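

In this assay, replacing piperidin-1-yl with diethylamino on a saturated chain carbon, three bonds along the chain from an oxygen on an aromatic ring, gives a 1.1-fold lower number from compound 3 to compound 4 (0.03 log units; within the scatter) and so leaves the reading unchanged within the usual scatter. The earlier compounds shown here could not show this, since each pair among them differs in more than one place, whereas here the amine at the end of the chain is the only thing that differs, so on this core the six-membered ring can be swapped for the open diethylamino group with no readable change in this assay. No supporting measurement is available to say why these two groups read alike, and their similar values alone do not explain it.

This single pair speaks only for these two amines, at this one place on this one core, and so does not establish a general tolerance for change there. Still open, going by these compounds, is whether morpholin-4-yl, dimethylamino or a primary amine at the end of the chain, a carboxylic acid in place of the amine, or a longer chain carrying diethylamino would stay as close as these two compounds do.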